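Does a longer selenium chain restore activity?

A few compounds are considered here, and "the series" means these few. Any claim that something is new, unique, unknown or untested is made for them only; others in the source may bear on it.

Values measured in a functional assay on MDA-MB-231 cells (Homo sapiens) for antiproliferative activity, read by MTT assay, with a stated time of 48 h; on this read-out lower numbers stand for stronger inhibition and higher numbers for weaker inhibition:
- compound 1 `COc1ccc(N(C)c2ccnc(Cl)n2)cc1O` gives 833 nM
- compound 2 `COc1ccc(N(C)c2ccnc(Cl)n2)cc1OCCC[Se]C#N` gives 1490 nM
- compound 3 `COc1ccc(N(C)c2ccnc(Cl)n2)cc1OCCCC[Se]C#N` gives > 10000 nM

For compound 3 the result > 10000 nM is a limit of the assay, not a number. Compound 4 `COc1ccc(N(C)c2ccnc(Cl)n2)cc1OCCCCC[Se]C#N` is the next structure to test, and it differs from compound 3 as follows: a group of 4 heavy atoms (2 carbon, 1 nitrogen, 1 selenium; no ring) in place of a group of 3 heavy atoms (1 carbon, 1 nitrogen, 1 selenium; no ring), on a saturated chain carbon, four bonds along the chain from an oxygen on an aromatic ring. Going by the values given here, the closest precedent is an at least 6.7-fold higher number from compound 2 to compound 3 (0.82 log units; beyond the scatter), a clear loss, whereas a 1.8-fold higher number from compound 1 to compound 2 (0.25 log units; within the scatter) stayed within the scatter. With only a limit for compound 3, the data cannot fix the next step, so weak inhibition is expected to persist in this assay. The estimated step is a number no higher from compound 3 to compound 4 (the limit leaves the size open), which means none beyond the scatter is expected. Compound 4 is estimated at 10000 nM, within an expected range of 2500 nM to 40000 nM.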

Compound 4, half-maximal inhibitory concentration: > 10000 nM
Compound 4 gave a limit, no number (the forecaster's own chance of this, stated with the estimate: 55%); the middle value sits exactly at the limit.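

In this assay compound 4 also gives a limit of the assay, not a number: the limit of > 10000 nM in this assay, at which 2 of the 4 values shown sit. The longer selenium chain therefore brings no return to a measured value, and the steps between the two limits cannot be read. The record still shows an at least 6.7-fold higher number from compound 2 to compound 4 (0.82 log units; beyond the scatter) and an at least 12-fold higher number from compound 1 to compound 4 (1.07 log units; beyond the scatter). On these data alone, how far past the limit compound 3 and compound 4 lie stays open. So does whether a shorter chain, or an amine or a carboxylic acid in place of the selenium group at the chain end, would give a measured value.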